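A few compounds are considered here, and "the series" means these few. Any claim that something is new, unique, unknown or untested is made for them only; others in the source may bear on it.

In a functional assay on SK-MEL-28 cells (Homo sapiens) for inhibition (on this read-out higher numbers stand for weaker inhibition and lower numbers for stronger inhibition), compound 1 `COc1cc2ccc(CCc3ccc4ccccc4c3)cc2cc1O` gives 3590 nM, and compound 2 `COCCOc1cc(/C=C\c2ccc3ccccc3c2)ccc1OC` gives 2990 nM, two values within the usual scatter of each other. Compound 3 `CC(=O)Oc1ccc(/C=C/c2ccc3ccccc3c2)cc1` gives no number in this assay, and its entry of > 5000 nM is a limit of the assay. Compound 3 thus stands at the limit of > 5000 nM in this assay, at which 1 of the 3 values shown sits, so its true position is not known.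

Compound 4 `COc1ccc(/C=C/c2ccc3ccccc3c2)cc1` differs from compound 3 in one place, with methyl in place of acetyl on an oxygen on an aromatic ring, acetoxy to methoxy: methyl in place of acetyl on an oxygen on an aromatic ring. Going by the values given here, no measured pair in this small set shows what such a change does, so any expectation has little to rest on. The closest guide is compound 2, which also has methoxy on an aromatic ring and gives 2990 nM. Compound 4 is therefore expected to give a number in this assay, though it may well remain at the limit. The expected step, an at least 1.6-fold lower number from compound 3 to compound 4 (0.22 log units; that floor lies within the scatter), runs towards stronger inhibition and is modest in size. For compound 4 the estimated value is 3000 nM, with an expected range from 900 nM to 6000 nM.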

Compound 4, half-maximal inhibitory concentration: > 5000 nM
Compound 4 was reported as a limit (the forecaster's own chance of this, stated with the estimate: 35%); middle value at least 1.6-fold (0.22 log units) away from the limit.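

In this assay compound 4 gives > 5000 nM, which is a limit and not a number. With compound 3 also at a limit, no step can be read between compound 3 and compound 4: the limit of > 5000 nM in this assay, at which 2 of the 4 values shown sit.

The compounds shown leave open what methyl in place of acetyl on an oxygen on an aromatic ring does to inhibition.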